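The compounds below may be only part of what the source reports. "The series", "measured", "known", "first", "only" and "open" are said of these compounds alone.

Measured compounds:
compound 1, `COc1ccc(/C=C/C(=O)c2ccc(OCCn3cc(CN4C(=O)/C=C/C(C)(C)C/C=C(\C)CC/C=C/4C)nn3)cc2O)cc1` — 3.24 ug/mL
compound 2, `COc1cccc(/C=C/C(=O)c2ccc(OCCn3cc(CN4C(=O)/C=C/C(C)(C)C/C=C(\C)CC/C=C/4C)nn3)cc2O)c1` — 0.95 ug/mL
compound 3, `COc1ccc(/C=C/C(=O)c2ccc(OCCCN3C(=O)/C=C/C(C)(C)C/C=C(\C)CC/C=C/3C)cc2)cc1` — 2.92 ug/mL

All three were tested in a functional assay on SW480 cells (Homo sapiens) for antiproliferative activity; a higher number here means a weaker inhibitor, a lower number a stronger inhibitor. Compound 1 and compound 2 share one core and differ only in the aromatic group on the chain: 3-methoxyphenyl in place of 4-methoxyphenyl on a double-bonded chain carbon bound to a double-bonded chain carbon. This change gave a 3.4-fold lower number from compound 1 to compound 2 (0.53 log units; beyond the scatter), a modest but real gain in potency for compound 2. Compound 3 carries a different core; the difference between the two cores is not broken down here. In this assay compound 3 gives a value that lies within the scatter of compound 1, so the two cannot be ordered, while compound 2 sits clearly lower than both.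

Compound 4, `COc1cccc(/C=C/C(=O)c2ccc(OCCCN3C(=O)/C=C/C(C)(C)C/C=C(\C)CC/C=C/3C)cc2)c1`, is the counterpart of compound 3 built on the same idea: 3-methoxyphenyl in place of 4-methoxyphenyl on a double-bonded chain carbon bound to a double-bonded chain carbon. The place of the change is described in the same words for both pairs, so it is the same change applied to the second core. Going by the values given here, nothing measured distinguishes how the two cores respond to it, and the only guide is the step seen from compound 1 to compound 2. On that basis compound 4 is expected to show a step of about a 3.1-fold lower number from compound 3 to compound 4 (0.49 log units; beyond the scatter), matching what was observed due to a 3.4-fold lower number from compound 1 to compound 2 (0.53 log units; beyond the scatter). Compound 4 is therefore estimated at 0.95 ug/mL in this assay, with a likely range from 0.45 ug/mL to 2.2 ug/mL, the width reflecting that a single precedent carries the whole expectation.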

Compound 4, half-maximal inhibitory concentration: 1.34 ug/mL
Estimate against measurement, compound 4: 1.4-fold (0.15 log units) below; low and high end bracket the measured number.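

In this assay, 3-methoxyphenyl in place of 4-methoxyphenyl on the second core gave a 2.2-fold lower number from compound 3 to compound 4 (0.34 log units; beyond the scatter) and so pointed the same way as on the first core, and the two steps cannot be told apart in size: the same change on two cores in this assay, a 3.4-fold lower number (0.53 log units; beyond the scatter) from compound 1 to compound 2 and a 2.2-fold lower number (0.34 log units; beyond the scatter) from compound 3 to compound 4, 1.6-fold (0.19 log units) apart, within the scatter of two such steps.

Within these two pairs, then, the change carries from one core to the other, and the step measured on the core of compound 1 was a fair guide to the step on the core of compound 3. Going by these compounds alone, this rests on only two cores and a single cell line, so it does not show that the change would hold on any further core or in other cells, and it says nothing about why the 3-methoxyphenyl compounds give the lower numbers.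

The compounds shown leave open whether an ethoxy group, a fluorine or an amine on the phenyl ring in place of the methoxy would follow the same trend. They also leave open how a longer chain between the aromatic part and the large ring would affect the step, and which of the differences between the two cores matter on their own.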